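From 2-fluoropyridin-4-yl to 1,2-thiazol-3-yl in compound 3

The source may report more compounds than this note shows. Statements on the series, on what has been measured and on what is new or still open speak of the compounds shown alone.

Values in a physicochemical assay for solubility, at pH 6.8; a higher number here means a more soluble compound, a lower number a less soluble compound
compound 1 `Cc1ccc(Cn2c(Nc3ccc(OC(C)C)c(Cl)c3)nc(=O)n(CCC(=O)O)c2=O)cc1` gives 169 ug/mL
compound 2 `C[C@@H](Cn1c(=O)[nH]/c(=N\c2ccc(Oc3ccccn3)cc2)n(Cc2ccc(Cl)cc2)c1=O)C(=O)O` gives 458 ug/mL
compound 3 `C[C@@H](Cn1c(=O)[nH]/c(=N\c2ccc(Oc3ccnc(F)c3)cc2)n(Cc2ccc(Cl)cc2)c1=O)C(=O)O` gives 212 ug/mL

Compound 3 reads 212 ug/mL in this assay and so sits within the scatter of compound 1 at 169 ug/mL on this scale. Compound 2 stands clearly higher at 458 ug/mL in the same measurement. The next compound to consider keeps the rest of compound 3 and alters only the ring attached through the oxygen. The change is 1,2-thiazol-3-yl in place of 2-fluoropyridin-4-yl on an oxygen on an aromatic ring and it gives compound 4 `C[C@@H](Cn1c(=O)[nH]/c(=N\c2ccc(Oc3ccsn3)cc2)n(Cc2ccc(Cl)cc2)c1=O)C(=O)O` with 1,2-thiazol-3-yl in place of 2-fluoropyridin-4-yl on an oxygen on an aromatic ring.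

Among the measured compounds shown here, only one measured step alters the group at this place, and it was modest: a 2.2-fold lower number from compound 2 to compound 3 (0.33 log units; beyond the scatter) with 2-fluoropyridin-4-yl in place of pyridin-2-yl. For the measured compounds named here, no measured compound carries 1,2-thiazol-3-yl, so that single step gives a rough size for a swap here but no firm direction. A step no larger than that modest one is expected in this assay and quite possibly none beyond the scatter, with a slight lean towards compound 2. The estimated change is a 1.1-fold higher number from compound 3 to compound 4 (0.05 log units; within the scatter) and it remains only an expectation. For compound 4 the expected value is 240 ug/mL with an estimated range from 110 ug/mL to 480 ug/mL until the measurement arrives.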

Compound 4, solubility: 650 ug/mL
Estimate against measurement, compound 4: 2.7-fold (0.43 log units) below, and the stated range ends below it.
By their numbers in this assay, from the lowest: compounds 1 and 3 (each within the scatter of the next); then compounds 2 and 4 (each within the scatter of the next).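

In this assay, replacing 2-fluoropyridin-4-yl with 1,2-thiazol-3-yl on the oxygen gives a 3.1-fold higher number from compound 3 to compound 4 (0.49 log units; beyond the scatter) and so shows that a swap at this place can raise the number as well as lower it. Among the compounds shown here, until now the only step here was a 2.2-fold lower number from compound 2 to compound 3 (0.33 log units; beyond the scatter) and it pointed downward, so the new result shows that the direction depends on the group involved. Pyridin-2-yl and 1,2-thiazol-3-yl give a 1.4-fold higher number from compound 2 to compound 4 (0.15 log units; within the scatter) and thus read alike, which means that a five-membered ring and a six-membered ring can match at this place and that, among these three compounds, the 2-fluoropyridin-4-yl of compound 3 is the one that stands apart.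

Nothing in the data at hand accounts for these differences. The compounds shown also leave open how a pyridin-4-yl without the fluorine would read on this oxygen, so the effect of the fluorine cannot be separated from that of the ring's point of attachment, and a plain phenyl ring or an isomeric 1,2-thiazol-5-yl would be equally open.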